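Chloro for hydrogen on the pendant phenyl ring

A few compounds are considered here, and "the series" means these few. Any claim that something is new, unique, unknown or untested is made for them only; others in the source may bear on it.

Two compounds bearing a lipoyl amide tethered through a triazole to a coumarin core have been examined in a functional assay on PC-12 cells (Rattus norvegicus) for cytotoxicity, read by MTT assay, with stated times of 3 h and 2 h, tested at 0.1 uM; a lower number here means a weaker effect, a higher number a stronger effect of the compound at the concentration tested. Compound 1, `O=C(CCCCC1CCSS1)NCc1cn(CCCOc2ccc3cc(-c4ccc(Br)cc4)c(=O)oc3c2)nn1`, carries a bromophenyl group on the shared core and a three-carbon linker; in this assay compound 1 gives 39.5%. Compound 2, `O=C(CCCCC1CCSS1)NCc1cn(CCCCOc2ccc3cc(-c4ccccc4)c(=O)oc3c2)nn1`, carries an unsubstituted phenyl group and a four-carbon linker; in this assay compound 2 gives 38.6%. For the measured compounds named here, the two compounds differ in more than one place, so no single step connects them, and their two values lie within the scatter of each other: compound 2 stands alongside compound 1 rather than apart from it.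

Compound 3, `O=C(CCCCC1CCSS1)NCc1cn(CCCCOc2ccc3cc(-c4ccc(Cl)cc4)c(=O)oc3c2)nn1`, is the unmeasured member. It differs from compound 2 in one place, (chloro in place of hydrogen on an aromatic carbon). Going by the values given here, no step between measured compounds isolates this change, so the expectation rests on the closeness of compound 1 and compound 2. The author expects the step of a number 1.4 percentage points higher from compound 2 to compound 3 (within the scatter) to be none beyond the scatter. Compound 3 is accordingly estimated at 40%, with a range from 28% to 52%, because compound 1 with a halogen in the same position gives 39.5%.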

Compound 3, a percentage reported as activity, at one concentration (the size of the read-out at that concentration, not a potency): 38.8%
Estimate against measurement, compound 3: 1.2 percentage points above; the measured number falls inside the stated range.
By their numbers in this assay, from the lowest: compounds 2, 3 and 1 (each within the scatter of the next).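

For the compounds shown here, the change from phenyl to 4-chlorophenyl is now isolated for the first time, with the rest of the structure held fixed, and in this assay it amounts to a number 0.2 percentage points higher from compound 2 to compound 3 (within the scatter) at the one concentration tested. On this aromatic carbon, para to a large group, chloro in place of hydrogen therefore leaves the read-out within the scatter, something the earlier pair, which differs in more than one place, could not show. No measured evidence here bears on why the read-out holds at this position.

As far as these compounds go, whether a group of another kind on this carbon, such as an amine, a carboxylic acid or a methoxy group, would also leave the read-out within the scatter remains open, as does the swap from chloro to bromo with the chain held fixed. The part played by the chain length also stays unresolved, since compound 1 differs from compound 2 and from compound 3 in more than one place.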